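Ester variation on a sesquiterpene lactone core: cytotoxicity notes

The compounds below may be only part of what the source reports. "The series", "measured", "known", "first", "only" and "open" are said of these compounds alone.

Measured compounds:
- compound 1, `C=C1C(=O)O[C@H]2CC3=C[C@H](C/C(C)=C/[C@@H](OC(=O)c4ccc(C(C)=O)cc4)[C@H]12)OC3=O`: 2300 nM
- compound 2, `C=C1C(=O)O[C@H]2CC3=C[C@H](C/C(C)=C/[C@@H](OC(=O)CCCCBr)[C@H]12)OC3=O`: > 10000 nM
- compound 3, `C=C1C(=O)O[C@H]2CC3=C[C@H](C/C(C)=C/[C@@H](OC(=O)C(C)(C)CC)[C@H]12)OC3=O`: 2200 nM

In a functional assay on A549 cells (Homo sapiens) for cytotoxicity, read by MTT assay, with a stated time of 48 h (a higher number here means a weaker inhibitor, a lower number a stronger inhibitor), compound 1 gives 2300 nM and compound 3 gives 2200 nM; the two sit within the scatter of each other, as a 1.0-fold lower number from compound 1 to compound 3 (0.02 log units; within the scatter) shows. Compound 2 is the odd one out. Its value in this assay is a limit of the assay, not a number, and it stands at the limit of > 10000 nM in this assay, at which 1 of the 3 values shown sits. The steps from the other two esters to it are both clear: an at least 4.3-fold higher number from compound 1 to compound 2 (0.63 log units; beyond the scatter) and, read the other way, an at least 4.5-fold lower number from compound 2 to compound 3 (0.65 log units; beyond the scatter).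

The next compound, compound 4, `C=C1C(=O)O[C@H]2CC3=C[C@H](C/C(C)=C/[C@@H](OC(=O)/C=C/c4ccncc4)[C@H]12)OC3=O`, changes the ester once more: 2-(pyridin-4-yl)ethenyl in place of 4-bromobutyl on a carbonyl carbon. The two measured steps that bear on this position both show that leaving the 4-bromobutyl ester lowers the number at least modestly, whatever the replacement. A return toward the level of compound 1 and compound 3 is therefore expected, as a step of an at least 4.0-fold lower number from compound 2 to compound 4 (0.60 log units; beyond the scatter). Compound 4 is estimated at 2500 nM, with a range from 900 nM to 8000 nM.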

Compound 4, half-maximal inhibitory concentration: 4000 nM
Compound 4: middle estimate off by 1.6-fold (0.20 log units), on the low side; low and high end bracket the measured number.
By their numbers in this assay, from the lowest: compounds 3, 1 and 4 (each within the scatter of the next). At a limit, above all of these: compound 2.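

In this assay the 2-(pyridin-4-yl)ethenyl ester stands level with the two other esters, with a 1.7-fold higher number from compound 1 to compound 4 (0.24 log units; within the scatter) and a 1.8-fold higher number from compound 3 to compound 4 (0.26 log units; within the scatter). This position therefore accepts a six-membered aromatic ring with a hetero atom and a double bond outside aromatic rings, and among the four esters only the 4-bromobutyl ester of compound 2 falls away, with an at least 2.5-fold lower number from compound 2 to compound 4 (0.39 log units; beyond the scatter). Compound 2 remains a limit of the assay, not a number: the limit of > 10000 nM in this assay, at which 1 of the 4 values shown sits.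

The compounds shown do not separate the bromine of compound 2 from the chain that carries it. A plain butyl ester without bromine would address that point, and an ester carrying an amine or a carboxylic acid would test how far the shared level of compound 1, compound 3 and compound 4 extends.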